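The source may hold more compounds than are shown below. What is called first, only, known or untested is meant among the compounds shown, and "the series" means these compounds.

In a functional assay on MCF7 cells (Homo sapiens) for inhibition, read by MTT assay, with a stated time of 48 h, tested at 10 uM (a lower number here means less inhibition of growth, a higher number more inhibition of growth at the concentration tested), three related compounds have been measured so far. Compound 1 `Cc1cc(=O)c2c(O)cc(OCc3ccccc3)c([C@H]3CCN(C)C[C@H]3O)c2o1` gives 1%, compound 2 `Cc1oc2c([C@H]3CCN(C)C[C@H]3O)c(O)cc(O)c2c(=O)c1C(O)c1ccc(Cl)cc1` gives 6%, and compound 3 `Cc1oc2c([C@H]3CCN(C)C[C@H]3O)c(O)cc(O)c2c(=O)c1C(O)c1cccc(Cl)c1` gives 5%. Compound 3 therefore stands within the scatter of both other compounds, and the three numbers cannot be ranked.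

Compound 4 `Cc1oc2c([C@H]3CCN(C)C[C@H]3O)c(O)cc(O)c2c(=O)c1C(O)c1c(F)cccc1Cl` has not yet been measured. It keeps the core of compound 3 and differs in one place: 2-chloro-6-fluorophenyl in place of 3-chlorophenyl on a saturated chain carbon bound to an aromatic carbon and an oxygen on a saturated carbon. In words, 2-chloro-6-fluorophenyl takes the place of 3-chlorophenyl on a saturated chain carbon bound to an aromatic carbon and an oxygen on a saturated carbon.

Among the compounds with values here, only one measured step bears on this change. At the same place, the exchange of 4-chlorophenyl for 3-chlorophenyl gave a number 1 percentage points lower from compound 2 to compound 3 (within the scatter). Within the data shown here, that single step is a thin guide, since no measured compound carries 2-chloro-6-fluorophenyl. Among the measured compounds shown here, with this one small step as the only evidence, no change beyond the scatter is expected in this assay. The expected step is a number 1 percentage points higher from compound 3 to compound 4 (within the scatter). For compound 4, the estimated value is 6%, with an expected range from 0% to 16%.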

Compound 4, percent growth inhibition at one concentration: 41%
The estimate for compound 4 lay 35 percentage points below the measured number; measured number above the stated range.
By their numbers in this assay, from the lowest: compounds 1, 3 and 2 (each within the scatter of the next); then compound 4.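

In this assay, the saturated chain carbon bound to an aromatic carbon and an oxygen on a saturated carbon proves sensitive to the group it carries: 2-chloro-6-fluorophenyl gives a number 36 percentage points higher from compound 3 to compound 4 (beyond the scatter) and a number 35 percentage points higher from compound 2 to compound 4 (beyond the scatter), whereas the exchange between the two chlorophenyl groups had given only a number 1 percentage points lower from compound 2 to compound 3 (within the scatter). The earlier pair therefore gave no sign that this place could matter, and compound 4 is the only one of the compounds shown that stands beyond the scatter of the others. No measured information here accounts for this rise.

The entering group differs from both chlorophenyl groups in two ways at once, by its added fluorine and by the placing of its chlorine, so these steps cannot say which of the two carries the change. Going by these compounds, it also remains open whether a bromine or a methoxy group on this ring would preserve the rise, whether the hydroxy group on the chain carbon is required for it, and how the rise seen at a single concentration would translate across a range of concentrations.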